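A few compounds are considered here, and "the series" means these few. Any claim that something is new, unique, unknown or untested is made for them only; others in the source may bear on it.

Going by the values given here, compound 2 `Cc1cnc(Nc2ccc(S(N)(=O)=O)cc2)nc1Nc1nc2ccccc2s1` gives 2800 nM in a functional assay on HeLa cells (Homo sapiens) for antiproliferative activity, read by MTT assay, with a stated time of 48 h (on this read-out higher numbers stand for weaker inhibition and lower numbers for stronger inhibition), the only number in the set. Compound 1 `Cc1cnc(Nc2ccc(C(C)C)cc2)nc1Nc1nc2ccccc2s1` returns only a limit in this assay, > 50000 nM. Among the compounds with values here, the single measured step, an at least 17-fold lower number from compound 1 to compound 2 (1.25 log units; beyond the scatter), therefore rests on (the limit of > 50000 nM in this assay, at which 1 of the 2 values shown sits). Compound 3 `Cc1cnc(Nc2ccc(N3CCCCC3)cc2)nc1Nc1nc2ccccc2s1` differs from compound 2 by piperidin-1-yl in place of sulfamoyl on an aromatic carbon. The entering piperidin-1-yl carries 0 hydrogen-bond donors, as did the isopropyl of compound 1, so the measured step is expected to run backwards. The step of a 7.1-fold higher number from compound 2 to compound 3 (0.85 log units; beyond the scatter) is expected, with a fair chance that only a limit is returned. Compound 3 is estimated at 20000 nM, range 5000 nM to 50000 nM.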

Compound 3, half-maximal inhibitory concentration: 4340 nM
Compound 3: middle estimate off by 4.6-fold (0.66 log units), on the high side, and the stated range ends above it.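

Piperidin-1-yl, with 0 hydrogen-bond donors, serves at this position as well as sulfamoyl, with a 1.6-fold higher number from compound 2 to compound 3 (0.19 log units; within the scatter), so a donor on this group is not required in this assay. Donor count therefore does not separate the compounds, since isopropyl also carries none, yet the change to piperidin-1-yl gives an at least 11-fold lower number from compound 1 to compound 3 (1.06 log units; beyond the scatter). That step rests on a limit, the one held by compound 1: the limit of > 50000 nM in this assay, at which 1 of the 3 values shown sits.

Going by these compounds, whether a morpholine ring, a primary amine or a carboxylic acid at this position would match compound 3 stays open. Also open, on these data alone, is which feature of piperidin-1-yl sets it apart from isopropyl.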